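From Methylsulfanyl to Trifluoromethoxy: Expected Cytotoxicity

The source may report more compounds than this note shows. Statements on the series, on what has been measured and on what is new or still open speak of the compounds shown alone.

Compound 1, `O=c1[nH]c(=O)n([C@H]2C[C@H](O)[C@@H](CO)O2)cc1-c1cn(-c2ccccc2)nn1`: in an ADME assay on HEL cells (Homo sapiens) for cytotoxicity, read by cell counting, with a stated time of 3 days (on this read-out lower numbers stand for higher toxicity in this test and higher numbers for lower toxicity in this test), compound 1 gives 270000 nM.
Compound 2, `CSc1ccc(-n2cc(-c3cn([C@H]4C[C@H](O)[C@@H](CO)O4)c(=O)[nH]c3=O)nn2)cc1`: in this assay compound 2 gives > 230000 nM.

The value of compound 2 is a limit of the assay, not a number, so compound 2 stands only at the edge of the measured range, not at a point within it. Among the compounds with values here, the one measured step, a step that the limit leaves unreadable from compound 1 to compound 2, is of unreadable size because of the limit of > 230000 nM in this assay, at which 1 of the 2 values shown sits, which leaves its direction open as well.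

Compound 3, `O=c1[nH]c(=O)n([C@H]2C[C@H](O)[C@@H](CO)O2)cc1-c1cn(-c2ccc(OC(F)(F)F)cc2)nn1`, differs from compound 2 in one place: trifluoromethoxy in place of methylsulfanyl on an aromatic carbon. Within the data shown here, no measured step touches this change directly, and the single step that exists cannot be read. Among the measured compounds shown here, since the only guide is a limit, compound 3 is expected to sit near the same region as compound 2, with no step beyond the scatter foreseen; the step from compound 2 to compound 3 is estimated as a step that the limit leaves unreadable from compound 2 to compound 3. In this assay compound 3 is therefore estimated at 250000 nM, within a range from 100000 nM to 500000 nM.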

Compound 3, minimum cytotoxic concentration: > 220000 nM
Compound 3: no number, only a limit; the forecaster's own chance of this, stated with the estimate: 65%; the middle value lies beyond the limit too.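

In this assay compound 3 gives > 220000 nM, which is a limit of the assay and not a number. Within the data shown here, no step from compound 1 or compound 2 to compound 3 can be read. The compounds shown leave open whether trifluoromethoxy, methylsulfanyl and hydrogen on the aromatic carbon differ at all in this assay.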